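This account rests on a few compounds, and the source may have more. Where it says the series, first, only, none or still open, it means among the compounds named here.

Among the compounds with values here, in a functional assay on CCRF-CEM cells (Homo sapiens) for inhibition, read by sulforhodamine B assay, with a stated time of 48 h (a higher number here means a weaker inhibitor of growth, a lower number a stronger inhibitor of growth), compound 1 `Nc1cc(N)c2nc(-c3ccccc3)c(NCc3ccc(Cl)c(Cl)c3)nc2c1` gives 1820 nM, the only complete number in this set. Compound 2 `Nc1cc(N)c2nc(-c3ccccc3)c(Sc3ccc(Cl)c(Cl)c3)nc2c1` gives only a limit here, < 100000 nM. Compound 3 `CCOC(=O)[C@H](CCC(=O)O)NC(=O)c1ccc(Oc2nc3cc(N)cc(N)c3nc2-c2ccccc2)cc1` likewise gives only a limit, < 100000 nM. Compound 1 therefore stands alone with a measured number, beside (the limit of < 100000 nM in this assay, at which 2 of the 3 values shown sit).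

Compound 4 `COc1ccc(CNc2nc3cc(N)cc(N)c3nc2-c2ccccc2)cc1OC` is built from compound 1 by one change: 3,4-dimethoxyphenyl in place of 3,4-dichlorophenyl on a saturated chain carbon bound to a nitrogen on an aromatic ring. Within the data shown here, no measured pair in the set shows this kind of swap, so nothing here tells its effect directly. The change is expected to be a 2.2-fold higher number from compound 1 to compound 4 (0.34 log units; beyond the scatter), a modest shift toward weaker growth inhibition that may not clear the usual scatter. Compound 4 is thus estimated at 4000 nM, within a range from 1000 nM to 20000 nM.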

Compound 4, concentration for total growth inhibition: 70800 nM
Beside the measured number, compound 4's estimate is 18-fold (1.25 log units) below it; the measured number lies above the stated range.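

In this assay, within the data shown here, putting 3,4-dimethoxyphenyl in place of 3,4-dichlorophenyl gives a 39-fold higher number from compound 1 to compound 4 (1.59 log units; beyond the scatter), the first step in this set that can be read as a measured change. At this position, then, growth inhibition depends strongly on which group the saturated chain carbon carries, though the data give no reason for it. Compounds 2 and 3 offer no such comparison, as each gives only a limit: the limit of < 100000 nM in this assay, at which 2 of the 4 values shown sit.

As far as these compounds go, it remains open whether a single chlorine, a single methoxy or a fluorine on this ring would behave like compound 1 or like compound 4.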